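Phenyl in place of a sulfonyl group

A few compounds are considered here, and "the series" means these few. Any claim that something is new, unique, unknown or untested is made for them only; others in the source may bear on it.

Measured in a functional assay on MDA-MB-231 cells (Homo sapiens) for antiproliferative activity, read by MTT assay, with a stated time of 96 h; a higher number here means a weaker inhibitor, a lower number a stronger inhibitor:

compound 1 `CC(C)=CCC/C(C)=C/CC/C(C)=C/CC[C@]1(C)CCc2cc(OC(=O)NS(=O)(=O)c3ccc(C)cc3)cc(C)c2O1` gives 6600 nM
compound 2 `CC(C)=CCC/C(C)=C/CC/C(C)=C/CC[C@]1(C)CCc2c(C)c(OC(=O)NS(=O)(=O)c3ccccc3)c(C)c(C)c2O1` gives > 10000 nM as a limit of the assay
compound 3 `Cc1c(C)c2c(c(C)c1OC(=O)[C@@H](N)CCCCN)CC[C@@](C)(CCCC(C)CCCC(C)CCCC(C)C)O2` gives "not determined" (no result reported)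

Compound 1 is the only one of the three with an actual number. The entry for compound 2 is a limit of the assay. Compound 3 has no result.

Compound 4 (`CC(C)=CCC/C(C)=C/CC/C(C)=C/CC[C@]1(C)CCc2cc(OC(=O)Nc3ccccc3)cc(C)c2O1`) keeps the core of compound 1 and differs from it in one place: phenyl in place of (4-methylphenyl)sulfonyl on an amide-type nitrogen. Among the compounds with values here, no measured pair in this assay tests this change, so the expectation rests on compound 1 alone (6600 nM). The step is expected to stay within the usual scatter, with no clear direction (a 1.3-fold lower number from compound 1 to compound 4 (0.12 log units; within the scatter)). The estimate for compound 4 is 5000 nM with an expected range from 2000 nM to 12000 nM and the measurement still to come.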

Compound 4, half-maximal inhibitory concentration: > 10000 nM
Compound 4 ended at the assay's limit (the forecaster's own chance of this, stated with the estimate: 25%); at least 2.0-fold (0.30 log units) between middle value and limit.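

In this assay compound 4 gives > 10000 nM, which is a limit of the assay and not a number. The exchange of (4-methylphenyl)sulfonyl for phenyl on the amide-type nitrogen therefore reads as an at least 1.5-fold higher number from compound 1 to compound 4 (0.18 log units; that floor lies within the scatter), so this first test of the position shows no gain, but its floor does not establish a loss. How far the change really reaches cannot be read from this result, because the value stops at the assay's ceiling: the limit of > 10000 nM in this assay, at which 2 of the 4 values shown sit.

The compounds shown leave open how much of the step belongs to the sulfonyl and how much to the ring methyl, which a 4-methylphenyl or a phenylsulfonyl group on the same nitrogen could separate. Also open, as far as these compounds go, is whether a carboxylic acid or an amine on that phenyl ring would give a measurable value.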